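Replacing the aryl on the piperazine with a chlorophenylpropyl chain

The source may report more compounds than this note shows. Statements on the series, on what has been measured and on what is new or still open speak of the compounds shown alone.

Of the compounds shown here, three sharing one core have been measured in an assay on CHO cells for displacement of a labelled ligand from adenosine receptor A3 (Homo sapiens), read by scintillation counting, with a stated time of 120 min, tested at 10 uM; on this read-out lower numbers stand for less inhibition and higher numbers for more inhibition at the one concentration tested (going by the name of the read-out). Compound 1 `Nc1scc(CN2CCN(c3ccncc3)CC2)c1C(=O)c1ccc(Cl)cc1` gives 2% in this assay. Compound 2 `Nc1scc(CN2CCN(c3ccc(F)cc3F)CC2)c1C(=O)c1ccc(Cl)cc1` gives 0%. Compound 3 `Nc1scc(CN2CCN(c3c(F)cccc3F)CC2)c1C(=O)c1ccc(Cl)cc1` gives 4%. Compound 3 stands highest of the three numbers, though its separation from its nearest neighbour, a number 2 percentage points higher from compound 1 to compound 3 (within the scatter), and from the furthest, a number 4 percentage points higher from compound 2 to compound 3 (within the scatter), both lie within the scatter, so the three values cannot be ordered.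

Compound 4 `Nc1scc(CN2CCN(CCCc3ccc(Cl)cc3)CC2)c1C(=O)c1ccc(Cl)cc1` differs from compound 3 in one place: 3-(4-chlorophenyl)propyl in place of 2,6-difluorophenyl on an amine nitrogen in a ring.

Among the compounds with values here, none of the measured steps touches this kind of change. The steps of a number 2 percentage points lower from compound 1 to compound 2 (within the scatter) and a number 4 percentage points higher from compound 2 to compound 3 (within the scatter) only exchange one aryl for another on the amine nitrogen in the ring and stay within the scatter, as does a number 2 percentage points higher from compound 1 to compound 3 (within the scatter). They show that the three aryl groups tried so far give flat, low inhibition; they say nothing about a chain with a chlorophenyl at its end. The expected step of a number 1 percentage points higher from compound 3 to compound 4 (within the scatter) is therefore small, with no direction beyond the scatter supported by the data. Compound 4 is expected to give about 5%, in a range from -5% to 20%, in this assay.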

Compound 4, a percentage reported as inhibition, at one concentration (the size of the read-out at that concentration, not a potency): 0%
The estimate for compound 4 lay 5 percentage points above the measured number; low and high end bracket the measured number.
By their numbers in this assay, from the lowest: compounds 2, 4, 1 and 3 (each within the scatter of the next).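

Replacing the directly attached aryl with 3-(4-chlorophenyl)propyl on the amine nitrogen in the ring gives a reading in this assay that cannot be told apart from any of the three earlier compounds (a number 4 percentage points lower from compound 3 to compound 4 (within the scatter); no change at the digits printed from compound 2 to compound 4 (within the scatter); a number 2 percentage points lower from compound 1 to compound 4 (within the scatter)). The flat readings at this position therefore extend beyond the three aryl groups to a group with a three-carbon chain before its aromatic ring, and none of the four compounds stands apart from the others. No supporting data bear on why the reading stays flat across this change.

As far as these compounds go, it remains open whether a chain ending in an amine or a carboxylic acid, a longer chain, or an amide on this nitrogen would give a reading beyond the scatter in this assay. Since all four readings come from a single concentration and sit close together, they also leave open whether a change elsewhere on the shared core, such as an amine in place of the chlorine on the benzoyl ring, would matter more than any change at this nitrogen.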